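A few compounds are considered here, and "the series" means these few. Any claim that something is new, unique, unknown or untested is made for them only; others in the source may bear on it.

In a functional assay on MCF7 cells (Homo sapiens) for antiproliferative activity, read by MTT assay (a lower number here means a stronger inhibitor, a higher number a weaker inhibitor), compound 1 `NS(=O)(=O)c1cccc(/N=C2\NC(=O)/C(=C3/C(=O)Nc4ccccc43)S2)c1` gives only a limit, > 200000 nM. Compound 2 `NS(=O)(=O)c1ccc(/N=C2\NC(=O)/C(=C3/C(=O)Nc4ccc(F)cc43)S2)cc1` gives 20500 nM, the higher of the two actual numbers. Compound 3 `NS(=O)(=O)c1ccc(/N=C2\NC(=O)/C(=C3/C(=O)Nc4ccc(Cl)cc43)S2)cc1` gives 3960 nM. The next change leads to compound 4 `NS(=O)(=O)c1ccc(/N=C2\NC(=O)/C(=C3/C(=O)Nc4ccc(Br)cc43)S2)cc1`, with bromo in place of fluoro on an aromatic carbon. Among the compounds with values here, one measured step bears on this, the replacement of the same fluoro by chloro, which gave a 5.2-fold lower number from compound 2 to compound 3 (0.71 log units; beyond the scatter). Within the data shown here, that modest step is the only guide, so a step of similar size towards a lower number is expected in this assay. The expected step is a 6.4-fold lower number from compound 2 to compound 4 (0.81 log units; beyond the scatter). For compound 4 the estimated value is 3200 nM, within an expected range of 1100 nM to 9500 nM.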

Compound 4, half-maximal inhibitory concentration: 11300 nM
Beside the measured number, compound 4's estimate is 3.5-fold (0.55 log units) below it; measured number outside the range, above it.
By their numbers in this assay, from the lowest: compound 3; then compounds 4 and 2 (each within the scatter of the next). At a limit, above all of these: compound 1.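

In this assay, the halogen on this aromatic carbon gives no steady trend from fluoro through chloro to bromo: bromo in place of fluoro gives a 1.8-fold lower number from compound 2 to compound 4 (0.26 log units; within the scatter), while bromo in place of chloro gives a 2.9-fold higher number from compound 3 to compound 4 (0.46 log units; beyond the scatter). Chloro therefore stands apart from both other halogens at this position, which the fluoro and chloro pair alone could not show. No evidence at hand accounts for this result. Open, from the compounds shown here alone, is whether iodo, methyl, methoxy or nitro on the same carbon would match or pass compound 3.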